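Swapping the Aryl Group for a Sulfonamide Arm

The compounds below may be only part of what the source reports. "The series", "measured", "known", "first", "only" and "open" are said of these compounds alone.

Going by the values given here, compound 1 `O=C1O[C@H]([C@@H](O)Cn2cc(-c3ccc(Br)cc3)nn2)C(OCc2ccccc2)=C1OCc1ccccc1` is measured in a functional assay on A549 cells (Homo sapiens) for antiproliferative activity, read by MTT assay, with a stated time of 72 h (on this read-out higher numbers stand for weaker inhibition and lower numbers for stronger inhibition), at 750 nM, the only actual number among the three values shown. Compound 2 `Cc1ccc(-c2cn(C/C=C3\OC(=O)C(OCc4ccccc4)=C3OCc3ccccc3)nn2)cc1` gives in this assay only a limit, > 100000 nM. Compound 3 `O=C1O/C(=C\Cn2cc(-c3cc(F)cc(F)c3)nn2)C(OCc2ccccc2)=C1OCc1ccccc1` likewise reaches only a limit, > 100000 nM. Among the compounds with values here, the one step between measured compounds, a step that the two limits leave unreadable from compound 2 to compound 3, therefore cannot be sized, as the limit of > 100000 nM in this assay, at which 2 of the 3 values shown sit, shows. Compound 4 `Cc1ccc(S(=O)(=O)NCc2cn(C[C@H](O)[C@H]3OC(=O)C(OCc4ccccc4)=C3OCc3ccccc3)nn2)cc1` differs from compound 1 by (((4-methylphenyl)sulfonyl)amino)methyl in place of 4-bromophenyl on an aromatic carbon. No measured step touches this change, so the shown data give neither its size nor its direction. The expectation is that compound 4 comes out somewhat weaker than compound 1, with a step of a 4.0-fold higher number from compound 1 to compound 4 (0.60 log units; beyond the scatter). Compound 4 is estimated at 3000 nM, between 500 nM and 30000 nM.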

Compound 4, half-maximal inhibitory concentration: 16800 nM
Compound 4: middle estimate off by 5.6-fold (0.75 log units), on the low side, within the range that was stated.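

The aromatic carbon that bears 4-bromophenyl in compound 1 is sensitive to what sits there: (((4-methylphenyl)sulfonyl)amino)methyl in its place gives a 22-fold higher number from compound 1 to compound 4 (1.35 log units; beyond the scatter). Going by these compounds alone, no earlier step could show this for the position. The loss is not total, as compound 4 still gives a real number rather than a limit of the assay: the limit of > 100000 nM in this assay, at which 2 of the 4 values shown sit.

The swap changes the whole group at once, so the compounds shown do not tell which part of the sulfonamide arm matters. A plain benzyl group or an aminomethyl group on this carbon would help separate those parts.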